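Replacing the Amide-Bearing Arm on an Aromatic Nitrogen

The source may report more compounds than this note shows. Statements on the series, on what has been measured and on what is new or still open speak of the compounds shown alone.

Compound 1 `CCOC(=O)C1=Cc2ccccc2OC1(OCc1cn(CC(=O)Nc2cccc(Cl)c2)nn1)C(F)(F)F`: 12800 nM
Compound 2 `O=C(O)C1=Cc2ccccc2OC1(OCc1cc(-c2ccc(F)cc2F)no1)C(F)(F)F`: > 150000 nM

Among the measured compounds shown here, in a functional assay on A549 cells (Homo sapiens) for inhibition, read by MTT assay, with a stated time of 24 h (a lower number here means a stronger inhibitor, a higher number a weaker inhibitor), compound 1 gives 12800 nM and stands as the only plain number among the two results. For compound 2 the result > 150000 nM is a limit of the assay (the limit of > 150000 nM in this assay, at which 1 of the 2 values shown sits). For the measured compounds named here, no step between two measured compounds that differ in one place is available. Compound 3 `CCOC(=O)C1=Cc2ccccc2OC1(OCc1cn(-c2ccc(C)cc2)nn1)C(F)(F)F` differs from compound 1 in one place: 4-methylphenyl in place of ((3-chlorophenyl)carbamoyl)methyl on an aromatic nitrogen. Going by the values given here, with no comparable step to lean on, the change is expected to cost a little potency, a 1.7-fold higher number from compound 1 to compound 3 (0.24 log units; within the scatter), though possibly not beyond the usual scatter. Compound 3 is therefore estimated at 22000 nM, between 6000 nM and 80000 nM.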

Compound 3, half-maximal inhibitory concentration: 19700 nM
Estimate against measurement, compound 3: 1.1-fold (0.05 log units) above; the range from low to high includes it.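

In this assay, the exchange gives a 1.5-fold higher number from compound 1 to compound 3 (0.19 log units; within the scatter), so the two compounds cannot be told apart. On this aromatic nitrogen, then, the whole ((3-chlorophenyl)carbamoyl)methyl arm, with its amide hydrogen, carbonyl and chlorine, can give way to the smaller 4-methylphenyl without a change beyond the scatter. No measured property shown bears on this step. As far as these compounds go, whether an amine or a carboxylic acid on that phenyl ring, or a longer chain on the aromatic nitrogen, would move the number beyond the scatter remains open.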